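From compound 2 to compound 3: an aryl swap

This account rests on a few compounds, and the source may have more. Where it says the series, first, only, none or still open, it means among the compounds named here.

Going by the values given here, in an ADME assay on HEK293 cells (Homo sapiens) for cytotoxicity, read by MTT assay, with a stated time of 24 h (on this read-out higher numbers stand for weaker inhibition and lower numbers for stronger inhibition), compound 1 (`COC(=O)c1scc(-c2ccc(NC(=O)c3ccc(F)c(Cl)n3)cc2)c1OC`) is recorded as "not determined" (no result reported) and offers no number, while compound 2 (`COC(=O)c1scc(-c2ccc(NC(=O)c3cccc(I)c3)cc2)c1OC`) gives 42700 nM as the only number. Compound 3 (`COC(=O)c1scc(-c2ccc(NC(=O)c3ccc(C(F)(F)F)cc3)cc2)c1OC`) keeps the shared core and differs from compound 2 in one group on a carbonyl carbon (4-(trifluoromethyl)phenyl in place of 3-iodophenyl on a carbonyl carbon). Among the compounds with values here, no measured step exists to guide the expectation, so no shift beyond the usual scatter is expected in either direction in this assay for this change. The estimated step (a 1.1-fold lower number from compound 2 to compound 3 (0.03 log units; within the scatter)) therefore stays small. Compound 3 is expected at 40000 nM within an estimated range (15000 nM to 100000 nM).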

Compound 3, half-maximal inhibitory concentration: 48300 nM
Compound 3: the middle estimate sits 1.2-fold (0.08 log units) below what was measured, within the range that was stated.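

Placing 4-(trifluoromethyl)phenyl in place of 3-iodophenyl on a carbonyl carbon gives a 1.1-fold higher number from compound 2 to compound 3 (0.05 log units; within the scatter) in this assay and is the first step that can be read in this series. At this position, one carbon-only aromatic ring substituted in this way can stand in for the other without a shift beyond the scatter. Nothing available bears on the reason for this result.

Only these two aryl groups can be compared here. As far as these compounds go, the effect of a carboxylic acid or an amine on the phenyl ring, or of a saturated alkyl chain on the carbonyl carbon, remains open.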